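A few compounds are considered here, and "the series" means these few. Any claim that something is new, unique, unknown or untested is made for them only; others in the source may bear on it.

Among the measured compounds shown here, in a functional assay on SGC-7901 cells (Homo sapiens) for antiproliferative activity, read by MTT assay, with a stated time of 24 h (on this read-out lower numbers stand for stronger inhibition and higher numbers for weaker inhibition), compound 1 (`O=C(NNc1cccc(Cl)c1)c1cccc(NS(=O)(=O)c2cnc(O)nc2O)c1`) gives 11800 nM, the only true number so far. Compound 2 (`O=C(NNc1ccc(F)cc1)c1cccc(NS(=O)(=O)c2cnc(O)nc2O)c1`) reads > 20000 nM, which is a limit and not a number. Compound 3 (`O=C(NNC(=O)c1ccc(NS(=O)(=O)c2cnc(O)nc2O)cc1)c1ccc(F)cc1`) reads > 20000 nM, also a limit. The data therefore crowd against (the limit of > 20000 nM in this assay, at which 2 of the 3 values shown sit), and compound 2 has no exact position on the scale.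

Compound 4 (`O=C(NNC(=O)c1ccccc1Cl)c1cccc(NS(=O)(=O)c2cnc(O)nc2O)c1`) departs from compound 2 on the amine nitrogen whose other neighbour is the amide-type nitrogen: (2-chlorophenyl)carbonyl in place of 4-fluorophenyl on an amine nitrogen. In words, (2-chlorophenyl)carbonyl stands in place of 4-fluorophenyl. For the measured compounds named here, only one measured step bears on this nitrogen, an at least 1.6-fold higher number from compound 1 to compound 2 (0.22 log units; that floor lies within the scatter). That step is only a floor and lies within the scatter, and it exchanges one substituted phenyl group for another. Going by the values given here, no measured step shows what happens when a carbonyl enters at this place.

With so little to go on, no step beyond the scatter is expected in this assay, in either direction, and another reading at the limit is quite likely. The expected change is a number no higher from compound 2 to compound 4 (the limit leaves the size open). For compound 4 the estimated value is 20000 nM, with an expected range of 9000 nM to 45000 nM.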

Compound 4, half-maximal inhibitory concentration: 6070 nM
Compound 4: middle estimate off by 3.3-fold (0.52 log units), on the high side, outside the stated range (below it).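

In this assay, among the compounds shown here, the (2-chlorophenyl)carbonyl group on the amine nitrogen whose other neighbour is the amide-type nitrogen gives the first step at this place that lies beyond the scatter (an at least 3.2-fold lower number from compound 2 to compound 4 (0.51 log units; beyond the scatter)). This shows that a carbonyl at this place is compatible with a true reading in this series, whereas the earlier step here only exchanged one substituted phenyl group for another. Against the 3-chlorophenyl group, the same entering group stays within the scatter (a 1.9-fold lower number from compound 1 to compound 4 (0.29 log units; within the scatter)), so the gain holds against 4-fluorophenyl only, and its full size stays open because compound 2 sits at a limit and not at a number: the limit of > 20000 nM in this assay, at which 2 of the 4 values shown sit.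

The step from 4-fluorophenyl to (2-chlorophenyl)carbonyl brings in the carbonyl and changes the halogen on the ring together, and the compounds shown do not separate these two changes. As far as these compounds go, whether a plain benzoyl group, an acetyl group or a carbonyl carrying a longer chain on this nitrogen would keep a reading in the range of compound 4 also remains open.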